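A few compounds are considered here, and "the series" means these few. Any claim that something is new, unique, unknown or untested is made for them only; others in the source may bear on it.

Compound 1 `COC(=O)c1sc2cc(-c3ccsc3)cnc2c1N` and compound 2 `COC(=O)c1sc2cc(-c3cnc4ccccc4c3)cnc2c1N` share one core and differ only in the ring attached to it. In a functional assay on MCF7 cells (Homo sapiens) for inhibition, read by sulforhodamine B assay, with a stated time of 48 h (a lower number here means a stronger inhibitor of growth, a higher number a weaker inhibitor of growth), compound 1 gives 12700 nM, and compound 2 gives 9800 nM; these two numbers lie within the scatter of each other, so neither compound can be called the weaker inhibitor of growth. Compound 3 `COC(=O)c1sc2cc(-c3ccc(N)cc3)cnc2c1N` changes compound 1 in one place: 4-aminophenyl in place of thiophen-3-yl on an aromatic carbon. Among the measured compounds shown here, no measured pair shows what such a change does here, so the step of a 1.1-fold lower number from compound 1 to compound 3 (0.02 log units; within the scatter) is expected to stay within the scatter, in no clear direction. For compound 3 the estimated value in this assay is 12000 nM, with a range from 5000 nM to 30000 nM.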

Compound 3, concentration for 50% growth inhibition: 108000 nM
Estimate against measurement, compound 3: 9.0-fold (0.95 log units) below, outside the stated range (above it).
By their numbers in this assay, from the lowest: compounds 2 and 1 (each within the scatter of the next); then compound 3.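

The ring on this carbon is not a free choice: in this assay, 4-aminophenyl in place of thiophen-3-yl gives an 8.5-fold higher number from compound 1 to compound 3 (0.93 log units; beyond the scatter) and so weakens growth inhibition by more than the scatter. Thiophen-3-yl and the ring of compound 2 had given values within the scatter of each other, so only this step shows that the position responds to a change of ring. Still open, going by these compounds, is whether the amine or the six-membered ring itself matters. Plain phenyl on the same carbon would separate the two, and a 4-hydroxyphenyl would test another group at that spot. No measurement at hand explains the step.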